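The source may hold more compounds than are shown below. What is called first, only, known or untested is meant among the compounds shown, and "the series" means these compounds.

Of the compounds shown here, three built on one shared core have been measured in a functional assay on MGC-803 cells (Homo sapiens) for antiproliferative activity, read by CCK-8 assay, with a stated time of 72 h, tested at 8 uM; on this read-out higher numbers stand for a stronger effect at the one concentration tested and lower numbers for a weaker effect. Compound 1 `Nc1ccccc1NC(=O)c1ccc(CSC(=S)N2CCN(c3ccccc3)CC2)cc1` gives 87.4%; compound 2 `Nc1ccccc1NC(=O)c1ccc(CSC(=S)N2CCN(c3cccnc3)CC2)cc1` gives 76.9%; compound 3 `Nc1ccccc1NC(=O)c1ccc(CSC(=S)N2CCN(Cc3cccnc3)CC2)cc1` gives 64.6%. On these numbers compound 3 stands lowest of the three: the nearest is compound 2, with a number 12.3 percentage points lower from compound 2 to compound 3 (beyond the scatter), and the furthest is compound 1, with a number 22.8 percentage points lower from compound 1 to compound 3 (beyond the scatter). Compound 4 `Nc1ccccc1NC(=O)c1ccc(CSC(=S)N2CCN(c3cnccn3)CC2)cc1` has not yet been measured. It differs from compound 3 in one place: pyrazin-2-yl in place of (pyridin-3-yl)methyl on an amine nitrogen in a ring. For the measured compounds named here, two measured steps bear on this. The loss seen in a number 12.3 percentage points lower from compound 2 to compound 3 (beyond the scatter) came when an aromatic ring set directly on the ring nitrogen gave way to its (pyridin-3-yl)methyl counterpart, and compound 4 returns to an aromatic ring placed directly on that nitrogen, so part of that loss should be recovered. At the same time, a number 10.5 percentage points lower from compound 1 to compound 2 (beyond the scatter) shows a modest cost when phenyl gave way to a ring with one nitrogen, and pyrazin-2-yl carries two. Compound 4 is therefore expected to show a number 5.4 percentage points higher from compound 3 to compound 4 (within the scatter). That would place it near compound 2. The estimate for compound 4 in this assay is 70%, between 55% and 85%.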

Compound 4, a percentage reported as inhibition, at one concentration (the size of the read-out at that concentration, not a potency): 80.5%
Compound 4: the middle estimate sits 10.5 percentage points below what was measured, within the range that was stated.
By their numbers in this assay, from the lowest: compound 3; then compounds 2, 4 and 1 (each within the scatter of the next, the first and the last beyond it).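

Compound 4 shows that at this position, in this assay, a ring with two nitrogens set directly on the ring nitrogen still beats the (pyridin-3-yl)methyl group, with a number 15.9 percentage points higher from compound 3 to compound 4 (beyond the scatter) as the step. The count of ring nitrogens does not set a steady decline: the data give a number 3.6 percentage points higher from compound 2 to compound 4 (within the scatter) and a number 6.9 percentage points lower from compound 1 to compound 4 (within the scatter), while compound 2, which goes against any simple reading, stays beyond the scatter from compound 1 in its own step. Nothing measured here explains these differences.

On these data alone, whether the lower number of compound 3 goes with the one-carbon link or with its pyridine ring stays open, and a phenylmethyl group on the same nitrogen would separate the two. As far as these compounds go, each number is also a single reading at one concentration, so how potency ranks across these compounds remains unknown.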